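The source may report more compounds than this note shows. Statements on the series, on what has been measured and on what is new or still open speak of the compounds shown alone.

Compound 1 `CC1(C)CC12NC(=O)N(NC(=O)c1ccc(Br)cc1)C2=O` is tested in a functional assay on the whole organism (Hindlimb) for inhibition, with Mus musculus as the target, with a stated time of 4 h (on this read-out lower numbers stand for an effect already at smaller amounts and higher numbers for an effect only at larger amounts of compound), and gives 300 mg/kg. Within the data shown here, its only measured neighbour, compound 2 `CN(C)c1ccc(C(=O)NN2C(=O)NC3(CC3(C)C)C2=O)cc1`, gives 300 mg/kg in this assay, so the two stand level: no change at the digits printed from compound 1 to compound 2 (within the scatter). Compound 3 `CC1(C)CC12NC(=O)N(NC(=O)c1cccnc1)C2=O` differs from compound 1 in one place: pyridin-3-yl in place of 4-bromophenyl on a carbonyl carbon. Among the measured compounds shown here, no measured step bears directly on this exchange; the single known step, in which dimethylamino replaces bromo on an aromatic carbon, left this assay unchanged. Compound 3 is therefore expected to show no step beyond the scatter, no change at the digits printed from compound 1 to compound 3 (within the scatter), with an estimated 300 mg/kg in a range from 150 mg/kg to 600 mg/kg.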

Compound 3, minimum effective dose: 300 mg/kg
Estimate against measurement, compound 3: no gap at the digits printed; low and high end bracket the measured number.
By their numbers in this assay, from the lowest: compounds 1, 2 and 3 (each within the scatter of the next).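

Exchanging the whole aromatic ring on the carbonyl carbon, rather than only a group on that ring, gives no change at the digits printed from compound 1 to compound 3 (within the scatter) in this assay. The change from 4-bromophenyl to pyridin-3-yl brings a ring nitrogen and a hydrogen-bond acceptor, and neither shifts the read-out at this position. Nothing measured here explains this result.

The compounds shown leave open whether a non-aromatic group on the carbonyl carbon, such as a longer alkyl chain or a carboxylic acid, would differ. They also leave open how changes to the shared core would read.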